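Extending the amine chain of compound 3

This account rests on a few compounds, and the source may have more. Where it says the series, first, only, none or still open, it means among the compounds named here.

Three amines on a shared core have been measured in an ADME assay on L6 cells (Rattus norvegicus) for cytotoxicity; a higher number here means a weaker inhibitor, a lower number a stronger inhibitor. Compound 1 `COc1cc2c(cc1C(C)NCCCc1ccccc1)C=CC(C)(C)O2` gives 1080 nM. Compound 2 `COc1cc2c(cc1C(C)NC/C=C/c1ccccc1)C=CC(C)(C)O2` gives 14600 nM. Compound 3 `CCNC(C)c1cc2c(cc1OC)OC(C)(C)C=C2` gives 176000 nM, the highest number of the three.

The next compound is compound 4 `CCCCNC(C)c1cc2c(cc1OC)OC(C)(C)C=C2`, and its difference from compound 3 is ethyl in place of hydrogen on a saturated chain carbon, two bonds along the chain from an amine nitrogen. In words, this is ethyl in place of hydrogen on a saturated chain carbon, two bonds along the chain from an amine nitrogen.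

The closest measured change is a 160-fold higher number from compound 1 to compound 3 (2.21 log units; beyond the scatter), with hydrogen in place of benzyl at that same place. Read in reverse, it shows a large drop in the number when the chain carries benzyl there. The change a 12-fold higher number from compound 2 to compound 3 (1.08 log units; beyond the scatter), with methyl in place of 2-phenylethenyl, is also large and points the same way. Going by the values given here, both groups lost in these steps carry a ring, whereas the entering ethyl has none, and no measured compound here has a plain chain longer than that of compound 3. Only part of those drops is therefore expected, in the same direction, towards a lower number in this assay.

The expected change is a 3.5-fold lower number from compound 3 to compound 4 (0.55 log units; beyond the scatter). The estimated value for compound 4 is 50000 nM, with an expected range of 15000 nM to 130000 nM.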

Compound 4, half-maximal inhibitory concentration: 52500 nM
Compound 4: middle estimate off by 1.1-fold (0.02 log units), on the low side; the range from low to high includes it.
By their numbers in this assay, from the lowest: compound 1; then compound 2; then compound 4; then compound 3.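

Working notes: in this assay, a plain chain with no ring is enough to lower the number at this position, with a 3.4-fold lower number from compound 3 to compound 4 (0.53 log units; beyond the scatter); until now, every lower number at this position came with a ring-bearing group. That step is modest, and the phenyl end of the chain still counts for more: with methyl in place of phenyl on a saturated chain carbon, three bonds along the chain from an amine nitrogen, there is a 49-fold higher number from compound 1 to compound 4 (1.69 log units; beyond the scatter), a large step. The unsaturated, ring-bearing chain of compound 2 stays ahead of butyl by a modest margin, with a 3.6-fold higher number from compound 2 to compound 4 (0.56 log units; beyond the scatter), so among these four amines the ethylamino to butylamino change recovers only part of the drop seen with the phenyl-bearing chains.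

Nothing available bears on why the number moves with these chains. Still open, on these data alone, is whether a longer chain such as hexyl or octyl would lower the number further, and whether a hydroxyl group or a carboxylic acid at the end of the butyl chain would keep or lose the drop.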